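A few compounds are considered here, and "the series" means these few. Any claim that something is new, unique, unknown or untested is made for them only; others in the source may bear on it.

Measured compounds:
compound 1 `CCOC(=O)/C=C/c1ccncc1-c1ccc2ccccc2c1` with 53.3 nM in an assay on a protein complex for inhibition of CDK8/Cyclin C (Homo sapiens), with a stated time of 1 h; a lower number here means a stronger inhibitor, a higher number a weaker inhibitor
compound 2 `CNC(=O)CCc1ccncc1-c1ccc2ccccc2c1` with 21.1 nM in this assay

Compound 1 has the higher of the two numbers in this assay; its nearest neighbour is compound 2, and the step of a 2.5-fold lower number from compound 1 to compound 2 (0.40 log units; beyond the scatter) replaces the ester-bearing ethenyl chain with a methylcarbamoyl-bearing saturated chain. Compound 3 `O=C(/C=C/c1ccncc1-c1ccc2ccccc2c1)N1CCOCC1` keeps the double-bonded chain of compound 1 and changes only the carbonyl substituent: morpholin-4-yl in place of ethoxy on a carbonyl carbon. Within the data shown here, no measured pair shows exactly this exchange. Among the measured compounds shown here, the one step that bears on it, a 2.5-fold lower number from compound 1 to compound 2 (0.40 log units; beyond the scatter), also turns an ester into an amide, but it alters the chain at the same time, so it speaks to the carbonyl substituent only in part. Because that step a 2.5-fold lower number from compound 1 to compound 2 (0.40 log units; beyond the scatter) was modest and the present change is a narrower one, the expected step of a 1.8-fold lower number from compound 1 to compound 3 (0.25 log units; within the scatter) is a small gain or none beyond the scatter. Compound 3 is therefore estimated at 30 nM in this assay, with a range from 12 nM to 80 nM.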

Compound 3, half-maximal inhibitory concentration: 60.3 nM
The estimate for compound 3 lay 2.0-fold (0.30 log units) below the measured number; low and high end bracket the measured number.
By their numbers in this assay, from the lowest: compound 2; then compounds 1 and 3 (each within the scatter of the next).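

With the double-bonded chain held fixed, morpholin-4-yl in place of ethoxy on a carbonyl carbon gives a 1.1-fold higher number from compound 1 to compound 3 (0.05 log units; within the scatter) in this assay, so at this place a six-membered non-aromatic ring can stand in for ethoxy while the two compounds remain within the scatter of each other. The earlier step, a 2.5-fold lower number from compound 1 to compound 2 (0.40 log units; beyond the scatter), changed the chain and the carbonyl substituent together; the new pair shows that this one amide, on the unchanged double-bonded chain, does not repeat that step. Nothing measured here offers an explanation for the result.

The compounds shown leave open whether the saturated chain or the methylcarbamoyl group carries the step to compound 2, a question that methylcarbamoyl on the double-bonded chain, or ethoxycarbonyl on the saturated chain, would separate. They also leave open how this carbonyl position responds to a carboxylic acid, to a piperidine ring in place of morpholin-4-yl, or to a basic amine such as 4-methylpiperazin-1-yl.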